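The source may hold more compounds than are shown below. What is called first, only, known or untested is meant among the compounds shown, and "the series" means these compounds.

In a functional assay on the whole organism with Rattus norvegicus as the target (on this read-out lower numbers stand for an effect already at smaller amounts and higher numbers for an effect only at larger amounts of compound), compound 1 `CC(C)Oc1ccccc1-c1ncc(-c2nn[nH]n2)c(O)n1` gives 0.04 mg/kg while compound 2 `CCCCOc1ccccc1-c1ncc(-c2nn[nH]n2)c(O)n1` gives 0.07 mg/kg and compound 3 `CC(C)COc1ccccc1-c1ncc(-c2nn[nH]n2)c(O)n1` gives 0.1 mg/kg in the same read-out. Compound 1 sits at the low end of these numbers but is not separated from compound 2 beyond the scatter. Compound 4 `C=CCOc1ccccc1-c1ncc(-c2nn[nH]n2)c(O)n1` differs from compound 1 by allyl in place of isopropyl on an oxygen on an aromatic ring with allyl in place of isopropyl on an oxygen on an aromatic ring. The measured swaps on that oxygen stay small: a 1.8-fold higher number from compound 1 to compound 2 (0.24 log units; within the scatter) and a 2.5-fold higher number from compound 1 to compound 3 (0.40 log units; beyond the scatter) and a 1.4-fold higher number from compound 2 to compound 3 (0.15 log units; within the scatter) on the same read-out. Going by the values given here, no measured compound carries a double bond in this chain. A small move to a higher number is expected in this assay with the estimated step of a 1.8-fold higher number from compound 1 to compound 4 (0.24 log units; within the scatter) as the working figure. For compound 4 the estimate is 0.07 mg/kg with an expected range from 0.03 mg/kg to 0.17 mg/kg in this read-out.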

Compound 4, dose for 50% inhibition: 0.24 mg/kg
Compound 4: middle estimate off by 3.4-fold (0.54 log units), on the low side; measured number outside the range, above it.
By their numbers in this assay, from the lowest: compounds 1, 2 and 3 (each within the scatter of the next, the first and the last beyond it); then compound 4.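

In this assay, this position on the oxygen tolerates less than the saturated chains suggested: allyl in place of isopropyl gives a 6.0-fold higher number from compound 1 to compound 4 (0.78 log units; beyond the scatter), although both groups count 3 heavy atoms. The unsaturated chain also stands apart from the two other saturated chains, with a 2.4-fold higher number from compound 3 to compound 4 (0.38 log units; beyond the scatter) and a 3.4-fold higher number from compound 2 to compound 4 (0.54 log units; beyond the scatter), all beyond the scatter. Nothing available accounts for these steps. A straight propyl chain on this oxygen would give allyl its direct saturated comparison. As far as these compounds go, whether a propargyl or cyclopropylmethyl group follows allyl or the saturated chains remains open.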